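The compounds below may be only part of what the source reports. "The series", "measured", "known", "first", "only" and "open" are said of these compounds alone.

Measured so far in a functional assay on RT-112 cells (Homo sapiens) for antiproliferative activity, read by MTT assay, with a stated time of 72 h; a lower number here means a stronger inhibitor of growth, a higher number a weaker inhibitor of growth
Compound 1 `COc1cc(Nc2ncnc3c(NC(=O)Nc4cc(Cl)c(Cl)cc4Cl)cccc23)cc(OC)c1` gives 4890 nM
Compound 2 `COc1cc(Nc2ncnc3c(NC(=O)Nc4ccc(Cl)cc4Cl)cccc23)cc(OC)c1` gives 3060 nM
Compound 3 `COc1cc(Nc2ncnc3c(NC(=O)Nc4ccc(Cl)c(Cl)c4)cccc23)cc(OC)c1` gives 6230 nM

Compound 3 sits at the upper end of these numbers, level with compound 1 within the scatter. The gap to compound 2 is a modest one, seen in a 2.0-fold higher number from compound 2 to compound 3 (0.31 log units; beyond the scatter) and just beyond the scatter.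

Compound 4 `CCOC(=O)c1ccc(NC(=O)Nc2cccc3c(Nc4cc(OC)cc(OC)c4)ncnc23)cc1` carries 4-(ethoxycarbonyl)phenyl in place of 3,4-dichlorophenyl on an amide-type nitrogen, counted as 4-(ethoxycarbonyl)phenyl in place of 3,4-dichlorophenyl on an amide-type nitrogen and still untested.

The measured steps bear on this change only indirectly, as all of them stay among chlorinated phenyl groups. Removing one chloro gave a 1.6-fold lower number from compound 1 to compound 2 (0.20 log units; within the scatter) and also a 1.3-fold higher number from compound 1 to compound 3 (0.11 log units; within the scatter) and both lie within the scatter. Moving a chloro gave the modest step above. For the measured compounds named here, no measured compound carries an ester, so direction cannot be read from the data. On these small steps, the expected change is a 1.2-fold lower number from compound 3 to compound 4 (0.10 log units; within the scatter) and no clear shift beyond the scatter is expected. For compound 4 the estimated value is 5000 nM with an expected range from 1800 nM to 13000 nM in this series.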

Compound 4, concentration for 50% growth inhibition: 317 nM
Beside the measured number, compound 4's estimate is 16-fold (1.20 log units) above it; measured number below the stated range.
By their numbers in this assay, from the lowest: compound 4; then compounds 2, 1 and 3 (each within the scatter of the next, the first and the last beyond it).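

Unlike the steps among chlorinated phenyl groups, 4-(ethoxycarbonyl)phenyl in place of 3,4-dichlorophenyl on the amide-type nitrogen brings a large shift in this assay, with a 20-fold lower number from compound 3 to compound 4 (1.29 log units; beyond the scatter). The gain does not depend on the chlorinated group it is set against: replacing 2,4-dichlorophenyl gives a 9.7-fold lower number from compound 2 to compound 4 (0.98 log units; beyond the scatter), and replacing 2,4,5-trichlorophenyl gives a 15-fold lower number from compound 1 to compound 4 (1.19 log units; beyond the scatter), which makes compound 4 the strongest inhibitor of growth of the four and shows this position can shift the number much further than the chloro changes suggested. No evidence is available here to account for the gain.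

Open, as far as these compounds go, is whether the ethyl ester itself carries the gain or whether the loss of chloro contributes, which a plain phenyl group would help separate. A carboxylic acid, a primary amide or a longer ester chain in place of the ethyl ester also remains to be compared.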